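Removing one methyl from the 2,5-dimethylphenyl sulfonamide

The source may hold more compounds than are shown below. What is called first, only, known or untested is meant among the compounds shown, and "the series" means these compounds.

For the measured compounds named here, in a functional assay on M21 cells (Homo sapiens) for antiproliferative activity, read by sulforhodamine B assay, with a stated time of 48 h (a higher number here means a weaker inhibitor, a lower number a stronger inhibitor), compound 2 (`Cc1ccc(C)c(NS(=O)(=O)c2ccc(N3CCNC3=O)cc2)c1`) gives 27 nM and stands as the lower of the two numbers so far, while compound 1 (`CCc1ccccc1NS(=O)(=O)c1ccc(N2CCNC2=O)cc1`) gives 180 nM as the only comparison. Going by the values given here, the one measured step is a 6.7-fold lower number from compound 1 to compound 2 (0.82 log units; beyond the scatter) and is modest but beyond the scatter. It puts 2,5-dimethylphenyl in place of 2-ethylphenyl on a sulfonamide nitrogen, so two differences are folded into it and the data do not separate them.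

Compound 3 (`Cc1ccccc1NS(=O)(=O)c1ccc(N2CCNC2=O)cc1`) has hydrogen in place of methyl on an aromatic carbon meta to a large group and para to a methyl group, which reads as 2,5-dimethylphenyl to 2-methylphenyl. Compound 3 lacks this methyl as compound 1 does, yet carries 2-methylphenyl rather than 2-ethylphenyl, so only part of a 6.7-fold lower number from compound 1 to compound 2 (0.82 log units; beyond the scatter) is expected to be given back. The expected step is a 3.0-fold higher number from compound 2 to compound 3 (0.47 log units; beyond the scatter) in this assay with the number rising beyond the scatter. Compound 3 is estimated at 80 nM with 30 nM to 220 nM as the expected span.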

Compound 3, half-maximal inhibitory concentration: 150 nM
Compound 3: middle estimate off by 1.9-fold (0.27 log units), on the low side, within the range that was stated.
By their numbers in this assay, from the lowest: compound 2; then compounds 3 and 1 (each within the scatter of the next).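

In this assay, the step of a 5.6-fold higher number from compound 2 to compound 3 (0.74 log units; beyond the scatter) isolates the methyl meta to a large group and para to a methyl group, a single change that the earlier comparison had folded together with the difference between ethyl and methyl. The other single change, hydrogen in place of methyl on a saturated chain carbon bound to an aromatic carbon, gives a 1.2-fold lower number from compound 1 to compound 3 (0.08 log units; within the scatter), so 2-ethylphenyl and 2-methylphenyl cannot be told apart here, and among these three compounds only 2,5-dimethylphenyl stands clear of the others. Nothing available explains why this one methyl counts for so much in this assay.

Going by these compounds, it remains open whether that position needs a methyl in particular or would also accept another group, such as ethyl, methoxy, chlorine or an amine. On these data alone, it is also open whether the same methyl would give a similar step when added to the 2-ethylphenyl compound, which would show whether its contribution carries over from the 2-methylphenyl setting.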